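Removing one methoxy group from a trimethoxyphenyl chalcone hybrid

The compounds below may be only part of what the source reports. "The series", "measured", "known", "first", "only" and "open" are said of these compounds alone.

Compound 1 `COc1ccc(/C=C/C(=O)c2cc(-c3ccc(OC)c(OC)c3)n3nc(-c4ccccc4)cc3n2)cc1` gives 22000 nM in a functional assay on MDA-MB-231 cells (Homo sapiens) for antiproliferative activity, read by MTT assay, with a stated time of 24 h; on this read-out lower numbers stand for stronger inhibition and higher numbers for weaker inhibition. Compound 2 `COc1ccc(-c2cc(C(=O)/C=C/c3ccc(Cl)cc3)nc3cc(-c4ccccc4)nn23)cc1OC` gives 23700 nM in this assay. Compound 3 `COc1cc(-c2cc(/C=C/C(=O)c3ccccc3)nc3cc(-c4ccccc4)nn23)cc(OC)c1OC` gives 15800 nM in this assay.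

All three compounds share the same core and differ only in the substitution of their outer aromatic rings. Compound 3 has the lowest of the three numbers, but its gaps to compound 1 and to compound 2 both lie within the scatter of repeated measurements, so no ranking among them can be claimed. Among the measured compounds shown here, the one measured single change, a 1.1-fold higher number from compound 1 to compound 2 (0.03 log units; within the scatter), also lies within the scatter.

Compound 4 `COc1ccc(-c2cc(/C=C/C(=O)c3ccccc3)nc3cc(-c4ccccc4)nn23)cc1OC` differs from compound 3 in one place: hydrogen in place of methoxy on an aromatic carbon. For the measured compounds named here, no measured step touches this ring, so the only guidance comes from the general observation that every change made so far has left this assay essentially unmoved. The step of a 1.1-fold higher number from compound 3 to compound 4 (0.06 log units; within the scatter) is therefore expected to stay within the scatter. Compound 4 is estimated at 18000 nM, with a likely range from 8000 nM to 40000 nM.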

Compound 4, half-maximal inhibitory concentration: 11800 nM
The estimate for compound 4 lay 1.5-fold (0.18 log units) above the measured number; measured number inside the range.
By their numbers in this assay, from the lowest: compounds 4, 3, 1 and 2 (each within the scatter of the next).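

Taking 3,4,5-trimethoxyphenyl to 3,4-dimethoxyphenyl gives, in this assay, a 1.3-fold lower number from compound 3 to compound 4 (0.13 log units; within the scatter), so at this position hydrogen can stand in place of methoxy without a readable shift in the number. The steps at the other end of the molecule also stay inside the scatter: 2-benzoylethenyl in place of (2-(4-chlorophenyl)ethenyl)carbonyl gives a 2.0-fold lower number from compound 2 to compound 4 (0.30 log units; within the scatter), and 2-benzoylethenyl in place of (2-(4-methoxyphenyl)ethenyl)carbonyl gives a 1.9-fold lower number from compound 1 to compound 4 (0.27 log units; within the scatter). No available measurement speaks to why these numbers stay so close together.

The compounds shown leave open whether any change on this ring can move the number beyond the scatter. An amine, a carboxylic acid or a longer alkoxy chain at this position could test that, as could taking away the two remaining methoxy groups.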